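Ethoxy to Methyl: Expectation for Compound 3

The source may hold more compounds than are shown below. What is called first, only, known or untested is meant among the compounds shown, and "the series" means these compounds.

Compound 2 `CCOc1cc(C(=O)Nc2nn[nH]n2)nc(-c2ccccc2)c1` stands at the top of the two numbers gathered so far, with compound 1 `CC(C)c1ccc(-c2cc(Cl)cc(C(=O)Nc3nn[nH]n3)n2)cc1` sitting beyond the scatter beneath it. In a functional assay on the whole organism for inhibition, with Rattus norvegicus as the target, at a dose of 1 mg/kg by the oral route (on this read-out higher numbers stand for a stronger effect at the one dose given and lower numbers for a weaker effect), compound 2 gives 29%, while compound 1 gives 14%. Compound 3 `Cc1cc(C(=O)Nc2nn[nH]n2)nc(-c2ccccc2)c1` differs from compound 2 by a single change: methyl in place of ethoxy on an aromatic carbon. Within the data shown here, no measured pair shows this exchange, so nothing here tells its size. The account expects only a small drop in this assay, not beyond the scatter. Compound 3 is therefore estimated at 22%, between 8% and 40%. The expected step of a number 7 percentage points lower from compound 2 to compound 3 (within the scatter) stays within the scatter.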

Compound 3, a percentage reported as inhibition, in the whole organism at one dose (the size of the read-out at that dose, not a potency): 23%
Estimate against measurement, compound 3: 1 percentage points below, within the range that was stated.
By their numbers in this assay, from the lowest: compounds 1, 3 and 2 (each within the scatter of the next, the first and the last beyond it).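

In this assay, among these compounds, putting methyl in place of ethoxy on the aromatic carbon opposite the ring nitrogen gives a number 6 percentage points lower from compound 2 to compound 3 (within the scatter), the only step yet read at this position. This position therefore tolerates the exchange of ethoxy for the smaller methyl, with its one heavy atom and no hydrogen-bond acceptor, without a change beyond the scatter at this one dose. Nothing available explains this outcome.

From the compounds shown here alone, whether an amine, a carboxylic acid or a longer chain such as propoxy here would move the read-out beyond the scatter stays open. Also open, going by these compounds, is how a bare hydrogen at this position would compare.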